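A few compounds are considered here, and "the series" means these few. Any claim that something is new, unique, unknown or untested is made for them only; others in the source may bear on it.

Compound 1 `N#CC1=C(N)Oc2c(c3nc4ccccc4nc3c3ccccc23)C12C(=O)N(Cc1cnnn1-c1ccc(F)cc1)c1ccccc12` gives > 50000 nM in a functional assay on A549 cells (Homo sapiens) for antiproliferative activity, read by MTT assay, with a stated time of 48 h (a higher number here means a weaker inhibitor, a lower number a stronger inhibitor), which is a limit of the assay and not a number.
Compound 2 `COc1ccc(-n2nncc2CN2C(=O)C3(C(C#N)=C(N)Oc4c3c3nc5ccccc5nc3c3ccccc43)c3ccccc32)cc1` gives > 50000 nM in this assay, again a limit.
Compound 3 `COc1ccccc1-n1nncc1CN1C(=O)C2(C(C#N)=C(N)Oc3c(N)cc4nc5ccccc5nc4c32)c2ccccc21` gives 37500 nM in this assay.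

Among the three values, only compound 3 yields a number; the other two sit at the limit (the limit of > 50000 nM in this assay, at which 2 of the 3 values shown sit). Within the data shown here, the one step measured between single-point changes, a step that the two limits leave unreadable from compound 1 to compound 2, therefore has no readable size. Compound 4 `Cc1ccc(Cl)cc1-n1nncc1CN1C(=O)C2(C(C#N)=C(N)Oc3c(N)cc4nc5ccccc5nc4c32)c2ccccc21` differs from compound 3 by 5-chloro-2-methylphenyl in place of 2-methoxyphenyl on an aromatic nitrogen. Among the measured compounds shown here, no measured step touches this change, and the recorded step offers no size to lean on. The step of a 1.1-fold higher number from compound 3 to compound 4 (0.03 log units; within the scatter) is accordingly expected to stay within the scatter. Compound 4 is estimated at 40000 nM, between 15000 nM and 100000 nM, with a real chance that only a limit is reported.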

Compound 4, half-maximal inhibitory concentration: > 50000 nM
Compound 4: a limit, no number; the forecaster's own chance of this, stated with the estimate: 40%; middle value at least 1.2-fold (0.09 log units) away from the limit.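

Compound 4 gives only a limit of the assay, not a number. In this assay, 5-chloro-2-methylphenyl in place of 2-methoxyphenyl on the aromatic nitrogen gives an at least 1.3-fold higher number from compound 3 to compound 4 (0.12 log units; that floor lies within the scatter), so this change has a floor but no readable size. Compound 3 is now the only compound with a number, and the limit holds for most of the series: the limit of > 50000 nM in this assay, at which 3 of the 4 values shown sit.

The compounds shown leave open how far the value would move with an amine or a carboxylic acid on this phenyl ring. They also leave open whether any such group on the core of compound 3 would give a clear step in this assay.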